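The compounds below may be only part of what the source reports. "The series", "measured", "known", "first", "only" and "open" are said of these compounds alone.

Measured compounds:
compound 1, `COc1ccc(CNc2ncnc3c2ncn3C2CCCCO2)c(OC)c1`, in an ADME assay on K562 cells (Homo sapiens) for cytotoxicity, with a stated time of 72 h (on this read-out higher numbers stand for weaker inhibition and lower numbers for stronger inhibition), compound 1 gives only a limit, > 25000 nM.
compound 2, `COc1ccc(CNc2ncnc3c2ncn3C2CCCCO2)c(OC)c1OC`, in this assay compound 2 gives only a limit, > 37500 nM.
compound 3, `COc1ccc(OC)c(CNc2ncnc3c2ncn3C2CCCO2)c1`, in this assay compound 3 gives only a limit, > 50000 nM.

All three values in this assay are limits of the assay and not numbers, as shown by the limit of > 25000 nM in this assay, at which 1 of the 3 values shown sits, the limit of > 37500 nM in this assay, at which 1 of the 3 values shown sits, and (the limit of > 50000 nM in this assay, at which 1 of the 3 values shown sits). The change from compound 1 to compound 2 is methoxy in place of hydrogen on an aromatic carbon, and its step is a step that the two limits leave unreadable from compound 1 to compound 2. The difference between the core of compound 1 and the core of compound 3 is not broken down here.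

Compound 4, `COc1cc(OC)c(OC)cc1CNc1ncnc2c1ncn2C1CCCO1`, is not yet measured in this assay. It differs from compound 3 by methoxy in place of hydrogen on an aromatic carbon. This is the same kind of change as that from compound 1 to compound 2, but not the same: in compound 2 the entering methoxy sits ortho to two methoxy groups and meta to a large group, whereas in compound 4 it sits ortho to a methoxy group, meta to a methoxy group and para to a large group.

Going by the values given here, since the only measured instance of this change gave two limits and no readable step, and since compound 3 itself gives only a limit, compound 4 is expected to give a step that the limit leaves unreadable from compound 3 to compound 4 in this assay, most likely again as a limit. The estimate for compound 4 in this assay is 60000 nM, expected between 20000 nM and 200000 nM.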

Compound 4, half-maximal inhibitory concentration: > 100000 nM
Compound 4 ended at the assay's limit; the forecaster's own chance of this, stated with the estimate: 85%; middle value at least 1.6-fold (0.22 log units) away from the limit.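

In this assay compound 4 gives > 100000 nM, which is a limit of the assay and not a number. Compound 3 also gives only a limit, and the step between compound 3 and compound 4 cannot be read. All four values shown are limits, which leaves open at what concentration any of these compounds would reach half-maximal inhibition and whether methoxy in place of hydrogen on an aromatic carbon changes it.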